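A few compounds are considered here, and "the series" means these few. Any claim that something is new, unique, unknown or untested is made for them only; others in the source may bear on it.

Measured compounds:
compound 1 `CCOc1ccc2cc(C(=O)/C=C/c3c(/C=C/c4ccc(OC)cc4)cc(OC)cc3OC)c(=O)oc2c1`, 48100 nM
compound 2 `COc1ccc(/C=C/c2cc(OC)cc(OC)c2/C=C/C(=O)c2cc3cccc(C)c3oc2=O)cc1`, 20000 nM
compound 3 `COc1ccc(/C=C/c2cc(OC)cc(OC)c2/C=C/C(=O)c2cc3ccc(C)cc3oc2=O)cc1`, 2780 nM

Of the compounds shown here, three have been tested in an assay on isolated protein for inhibition of Amine oxidase [flavin-containing] B (Homo sapiens), read by fluorescence, with a stated time of 15 min; a lower number here means a stronger inhibitor, a higher number a weaker inhibitor. Compound 3 gives 2780 nM and stands lowest of the three. Compound 2 gives 20000 nM, and compound 1 gives 48100 nM.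

Compound 2 and compound 3 share the same atoms joined differently; the difference between their cores is a group of 12 heavy atoms (10 carbon, 2 oxygen; one six-membered aromatic ring of carbon only, one six-membered aromatic ring with 1 hetero atom) in place of a group of 12 heavy atoms (10 carbon, 2 oxygen; one six-membered aromatic ring of carbon only, one six-membered aromatic ring with 1 hetero atom), on a carbonyl carbon. This rearrangement produced a 7.2-fold lower number from compound 2 to compound 3 (0.86 log units; beyond the scatter).

Compound 3 and compound 1 differ by ethoxy in place of methyl on an aromatic carbon. That change produced a 17-fold higher number from compound 3 to compound 1 (1.24 log units; beyond the scatter), a large step in this assay.

Compound 4 `CCOc1cccc2cc(C(=O)/C=C/c3c(/C=C/c4ccc(OC)cc4)cc(OC)cc3OC)c(=O)oc12` has not yet been measured. It differs from compound 2 by ethoxy in place of methyl on an aromatic carbon. This is the same kind of change as that from compound 3 to compound 1, but not the same: in compound 1 the ethoxy sits meta to a fused ring and para to a fused ring, whereas in compound 4 it sits ortho to a fused ring and meta to a fused ring. Among the measured compounds shown here, on the core of compound 2 the effect of this change has not been measured, so the expectation rests on the one example available.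

Because a 17-fold higher number from compound 3 to compound 1 (1.24 log units; beyond the scatter) was large, compound 4 is expected to show a higher number than compound 2, with an estimated step of an 8.0-fold higher number from compound 2 to compound 4 (0.90 log units; beyond the scatter), set somewhat smaller than the earlier step since the place of the change differs. The estimate for compound 4 in this assay is 160000 nM, expected to lie between 40000 nM and 600000 nM.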

Compound 4, half-maximal inhibitory concentration: > 60000 nM
Compound 4 was reported as a limit; the forecaster's own chance of this, stated with the estimate: 35%; the middle value does not contradict the limit.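

In this assay compound 4 gives > 60000 nM and this is a limit of the assay, not a number: the limit of > 60000 nM in this assay, at which 1 of the 4 values shown sits. Ethoxy in place of methyl on an aromatic carbon gives an at least 3.0-fold higher number from compound 2 to compound 4 (0.47 log units; beyond the scatter), so the number rises on both cores where this change can be read: the same change on two cores in this assay, a 17-fold higher number (1.24 log units; beyond the scatter) from compound 3 to compound 1 and an at least 3.0-fold higher number (0.47 log units; beyond the scatter) from compound 2 to compound 4; the limit leaves it open whether they differ. This shows that the direction of the change carried over to the core of compound 2, but it does not show how large the step is there. The ethoxy of compound 4, ortho to a fused ring and meta to a fused ring, sits in a different place from that of compound 1. The data do not separate the difference in core from the difference in place.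

The compounds shown leave open how the number in this assay would respond to groups other than methyl and ethoxy on this ring. An amine, a carboxylic acid or a longer chain at either place would show whether the rise seen with ethoxy extends to other groups, and a measured value for compound 4 in place of the limit would be needed to compare the two steps in size.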